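This account rests on a few compounds, and the source may have more. Where it says the series, first, only, none or still open, it means among the compounds named here.

Within the data shown here, in a functional assay on MCF7 cells (Homo sapiens) for inhibition, read by MTT assay, with a stated time of 72 h (a lower number here means a stronger inhibitor, a higher number a weaker inhibitor), two amine analogues on the shared core have numbers so far. Compound 1 `C/C1=C\CC[C@@]2(C)O[C@@H]2[C@H]2OC(=O)[C@@H](CN3CCCC3)[C@@H]2C[C@@H]1O` gives 18000 nM and compound 2 `C/C1=C\CC[C@@]2(C)O[C@@H]2[C@H]2OC(=O)[C@@H](CN3CCCCC3)[C@@H]2C[C@@H]1O` gives 8000 nM as the lower of the two numbers. Compound 3 `C/C1=C\CC[C@@]2(C)O[C@@H]2[C@H]2OC(=O)[C@@H](CN3CCN(C)CC3)[C@@H]2C[C@@H]1O` is not yet measured and differs from compound 2 by 4-methylpiperazin-1-yl in place of piperidin-1-yl on a saturated chain carbon bound to a saturated ring carbon in one exchange, 4-methylpiperazin-1-yl in place of piperidin-1-yl on a saturated chain carbon bound to a saturated ring carbon. Among the measured compounds shown here, the one measured step bearing on this is a 2.3-fold lower number from compound 1 to compound 2 (0.35 log units; beyond the scatter) at that place, a modest change from pyrrolidin-1-yl to piperidin-1-yl. That exchange is a different one, so it suggests a size and gives no firm direction. A similarly modest move in this assay is expected, leaning tentatively towards a higher number. a 1.5-fold higher number from compound 2 to compound 3 (0.18 log units; within the scatter) is the expected step here. Compound 3 is estimated at 12000 nM with an expected range from 4500 nM to 30000 nM for now.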

Compound 3, half-maximal inhibitory concentration: 22000 nM
Compound 3: middle estimate off by 1.8-fold (0.26 log units), on the low side; low and high end bracket the measured number.
By their numbers in this assay, from the lowest: compound 2; then compounds 1 and 3 (each within the scatter of the next).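

In this assay, the saturated chain carbon bound to a saturated ring carbon now shows a second step beyond the scatter, a 2.8-fold higher number from compound 2 to compound 3 (0.44 log units; beyond the scatter), with 4-methylpiperazin-1-yl in place of piperidin-1-yl. Compound 2 therefore holds the lowest number of the three, with its steps to both other compounds beyond the scatter, while pyrrolidin-1-yl and 4-methylpiperazin-1-yl are not separated at this position: a 1.2-fold higher number from compound 1 to compound 3 (0.09 log units; within the scatter). No measurement at hand accounts for these differences.

From the compounds shown here alone, all three compounds carry a ring amine, so it remains open how an open-chain amine such as dimethylamino, or morpholin-4-yl, would compare at this position. Also open, going by these compounds, is whether piperazin-1-yl without the methyl group would stay with compound 3 or move towards compound 2.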